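Swapping 4-propylpiperazin-1-yl for dimethylamino on a shared core

The source may hold more compounds than are shown below. What is called first, only, known or untested is meant among the compounds shown, and "the series" means these compounds.

- compound 1 (`CCCCN1CCN(CCCCn2c3c(c4ccccc42)C(=O)c2c[n+]([O-])c4ccccc4c2C3=O)CC1`) gives 2150 nM
- compound 2 (`CCCN1CCN(CCCCn2c3c(c4ccccc42)C(=O)c2c[n+]([O-])c4ccccc4c2C3=O)CC1`) gives 870 nM

Both numbers come from a single test (a functional assay on A-375 cells (Homo sapiens) for cytotoxicity, read by MTT assay, with a stated time of 72 h; a lower number here means a stronger inhibitor, a higher number a weaker inhibitor), and compound 2 holds the lower of the two (870 nM). The next compound, compound 3 (`CN(C)CCCCn1c2c(c3ccccc31)C(=O)c1c[n+]([O-])c3ccccc3c1C2=O`), differs from compound 2 in one place (dimethylamino in place of 4-propylpiperazin-1-yl on a saturated chain carbon, four bonds along the chain from an aromatic nitrogen). Dimethylamino stands in place of 4-propylpiperazin-1-yl on a saturated chain carbon, four bonds along the chain from an aromatic nitrogen.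

For the measured compounds named here, only one measured step bears on this change, and it is a modest one (a 2.5-fold lower number from compound 1 to compound 2 (0.39 log units; beyond the scatter)). Going by the values given here, that step only shortened the propyl end of the group, whereas here the whole ring leaves, and no measured compound carries dimethylamino. A single step sets no rule, so a modest further fall in the number is expected, though a rise cannot be excluded. For compound 3 the expected value is 600 nM, with an estimated range from 180 nM to 2000 nM. This estimate amounts to an expected step (a 1.5-fold lower number from compound 2 to compound 3 (0.16 log units; within the scatter)).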

Compound 3, half-maximal inhibitory concentration: 470 nM
The estimate for compound 3 lay 1.3-fold (0.11 log units) above the measured number, and the stated range covers the measured number.
By their numbers in this assay, from the lowest: compounds 3 and 2 (each within the scatter of the next); then compound 1.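

In this assay, dimethylamino in place of 4-propylpiperazin-1-yl gives a 1.9-fold lower number from compound 2 to compound 3 (0.27 log units; within the scatter), so on this saturated chain carbon a group with no ring and far fewer heavy atoms gives a number that cannot be told apart from that of the larger group. The same replacement made on 4-butylpiperazin-1-yl gives a 4.6-fold lower number from compound 1 to compound 3 (0.66 log units; beyond the scatter), a modest step beyond the scatter, which leaves compound 1 alone at the higher end while compound 2 and compound 3 stay together. The numbers show how far the group can shrink at this place, but no measurement here says what lies behind these steps.

As far as these compounds go, it remains open whether any amine nitrogen is needed here at all, a question that a plain butyl group, a hydroxyl or a carboxylic acid at the same carbon would address. Also open, from the compounds shown here alone, is how a morpholine or piperidine ring, a primary amine or a longer chain leading to the dimethylamino group would fare, and whether these small differences would carry over to cells other than the ones tested here.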